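Aryl swap on the shared core: expectation for compound 4

This account rests on a few compounds, and the source may have more. Where it says the series, first, only, none or still open, it means among the compounds named here.

Three measured compounds share one core and differ only in the aryl group attached to it. Compound 3 `Cc1ncc([N+](=O)[O-])n1CCSc1nnc(-c2ccccc2Cl)o1` gives 32600 nM in a functional assay on SGC-7901 cells (Homo sapiens) for cytotoxicity, read by MTT assay, with a stated time of 48 h (a lower number here means a stronger inhibitor, a higher number a weaker inhibitor), the highest of the three numbers, though both others lie within the scatter of it. Compound 1 `CCOc1ccccc1-c1nnc(SCCn2c([N+](=O)[O-])cnc2C)o1` gives 30300 nM and compound 2 `Cc1ncc([N+](=O)[O-])n1CCSc1nnc(-c2ccccc2[N+](=O)[O-])o1` gives 30000 nM. All steps are flat: a 1.0-fold lower number from compound 1 to compound 2 (0.00 log units; within the scatter), a 1.1-fold higher number from compound 1 to compound 3 (0.03 log units; within the scatter) and a 1.1-fold higher number from compound 2 to compound 3 (0.04 log units; within the scatter). Compound 4 `Cc1ncc([N+](=O)[O-])n1CCSc1nnc(-c2ccc(N)nc2)o1` is the next case; its change from compound 3 is 6-aminopyridin-3-yl in place of 2-chlorophenyl on an aromatic carbon. Only the three flat steps bear on it, and each exchanged one group on the aryl ring rather than the ring itself, so they inform this change only indirectly. No step beyond the scatter is expected in this assay. For compound 4 the estimate is 30000 nM, range 12000 nM to 80000 nM, the expected step being a 1.1-fold lower number from compound 3 to compound 4 (0.04 log units; within the scatter).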

Compound 4, half-maximal inhibitory concentration: 30900 nM
Compound 4: middle estimate off by 1.0-fold (0.01 log units), on the low side, and the stated range covers the measured number.
By their numbers in this assay, from the lowest: compounds 2, 1, 4 and 3 (each within the scatter of the next).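

In this assay replacing the whole aryl ring, rather than one group on it, gives a 1.1-fold lower number from compound 3 to compound 4 (0.02 log units; within the scatter) and so stays flat. At this aromatic carbon of the shared core, 6-aminopyridin-3-yl, with its ring nitrogen and hydrogen-bond donor, reads the same as 2-chlorophenyl within the scatter. Nothing available explains this flatness.

Still open, on these data alone, is whether the number moves with a carboxylic acid on the aryl ring or with a saturated ring such as cyclohexyl at this position. As far as these compounds go, the effect of a longer chain between the sulfur and the core's other ring also remains open.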